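Swapping the sulfonyl aryl group on the shared core

The compounds below may be only part of what the source reports. "The series", "measured", "known", "first", "only" and "open" are said of these compounds alone.

Measured compounds:
compound 1 `C=CCNC(=O)n1c(-c2ccc(OC)cc2)cc(=O)c2c(OC)cc(OC)cc21` — 16000 nM
compound 2 `COc1ccc(-c2cc(=O)c3c(OC)cc(OC)cc3n2S(=O)(=O)c2cccc(Br)c2)cc1` — > 58600 nM

The two compounds share one core and differ only in the group on the aromatic nitrogen. In a functional assay on SUP-B15 cells (Homo sapiens) for antiproliferative activity, with a stated time of 72 h (on this read-out lower numbers stand for an effect already at smaller amounts and higher numbers for an effect only at larger amounts of compound), compound 1 gives 16000 nM. For compound 2 the assay reports only a limit, > 58600 nM, so its true value is not known. Among the measured compounds shown here, the one measured step, an at least 3.6-fold higher number from compound 1 to compound 2 (0.56 log units; beyond the scatter), shows that the (3-bromophenyl)sulfonyl group weakens the effect.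

Compound 3 `COc1ccc(-c2cc(=O)c3c(OC)cc(OC)cc3n2S(=O)(=O)c2ccc(C)cc2)cc1` keeps that sulfonyl and changes only its aryl part: 4-methylphenyl in place of 3-bromophenyl on a sulfonyl sulfur. For the measured compounds named here, no measured step covers this change, and the starting point is itself a limit (the limit of > 58600 nM in this assay, at which 1 of the 2 values shown sits), so the estimate rests on compound 2 alone. Compound 3 is expected to stay at or near that limit, with a step of an at least 1.0-fold lower number from compound 2 to compound 3 (0.02 log units; that floor lies within the scatter) that is not expected to be meaningful. The estimate for compound 3 is 55000 nM, within 15000 nM to 200000 nM.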

Compound 3, half-maximal effective concentration: > 44800 nM
Compound 3 was reported as a limit; the forecaster's own chance of this, stated with the estimate: 60%; the middle value is on the limit's open side.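

In this assay compound 3 is again reported only as a limit, > 44800 nM. Putting (4-methylphenyl)sulfonyl in place of allylcarbamoyl on the aromatic nitrogen gives an at least 2.8-fold higher number from compound 1 to compound 3 (0.44 log units; beyond the scatter), so the higher number seen with the 3-bromophenyl version also appears with an aryl group that has no bromine and carries only carbon. Because compound 2 and compound 3 are both known only as limits, the step between them cannot be read, and the two aryl groups cannot be ranked: the limit of > 44800 nM in this assay, at which 1 of the 3 values shown sits.

As far as these compounds go, the true values of compound 2 and compound 3 remain unknown. Also open, from the compounds shown here alone, is whether a sulfonyl aryl group bearing an amine or a carboxylic acid, or a carbamoyl group with a longer chain than allyl, would bring the number down to that of compound 1 or lower.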